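This account rests on a few compounds, and the source may have more. Where it says the series, first, only, none or still open, it means among the compounds named here.

Compound 1 `CCC[C@@H]1CN[C@H](C(=O)N2CCC[C@H]2C#N)C1` and compound 2 `C=CC[C@@H]1CN[C@H](C(=O)N2CCC[C@H]2C#N)C1` share one core and differ only in a side chain. In an assay on the whole organism (plasma, strain Sprague-Dawley) for inhibition of Dipeptidyl peptidase 4 (Rattus norvegicus), with a stated time of 6 h, at a dose of 1 mg/kg by the oral route (on this read-out higher numbers stand for more inhibition at the one dose given (going by the name of the read-out) and lower numbers for less inhibition), compound 1 gives 50%, while compound 2 gives 38%. Compound 2 thus holds the lower of the two numbers, the step of a number 12 percentage points lower from compound 1 to compound 2 (beyond the scatter) lying beyond the scatter. Compound 3 `CN(C)C(=O)C[C@@H]1CN[C@H](C(=O)N2CCC[C@H]2C#N)C1` alters that side chain again: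

dimethylcarbamoyl in place of vinyl on a saturated chain carbon bound to a saturated ring carbon

Among the measured compounds shown here, the single measured step swaps one short chain for another and does not closely resemble this change, so the step of a number 2 percentage points higher from compound 2 to compound 3 (within the scatter) is expected to stay within the scatter. Compound 3 is estimated at 40%, between 20% and 60%.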

Compound 3, a percentage reported as inhibition, in the whole organism at one dose (the size of the read-out at that dose, not a potency): 66%
Beside the measured number, compound 3's estimate is 26 percentage points below it, and the stated range ends below it.
By their numbers in this assay, from the lowest: compound 2; then compound 1; then compound 3.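

In this assay, dimethylcarbamoyl in place of vinyl gives a number 28 percentage points higher from compound 2 to compound 3 (beyond the scatter) and dimethylcarbamoyl in place of ethyl gives a number 16 percentage points higher from compound 1 to compound 3 (beyond the scatter). The earlier compounds shown here showed only a fall between two short hydrocarbon chains, whereas compound 3 shows that this position also accepts a larger group with a hydrogen-bond acceptor, and it stands above both. Nothing available explains this rise.

As far as these compounds go, whether the gain follows from the carbonyl, the added size or the two methyl groups on nitrogen remains open. A carboxylic acid, a primary amide or a longer chain at this place would help separate these readings.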